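From 4-ethylphenyl to phenethyl on a sulfur

The source may hold more compounds than are shown below. What is called first, only, known or untested is meant among the compounds shown, and "the series" means these compounds.

Compound 1 `CCc1ccc(SCc2ccc(C(=O)Nc3ccccc3N)cc2)cc1`: 79.1%
Compound 2 `Nc1ccccc1NC(=O)/C=C/c1ccc(CSCCc2ccccc2)cc1`: 10.6%

In a functional assay on HCT-116 cells (Homo sapiens) for inhibition, read by CCK-8 assay, with a stated time of 72 h, tested at 8 uM (a lower number here means less inhibition of growth, a higher number more inhibition of growth at the concentration tested), compound 1 stands highest of the two measured compounds, and the gap down to compound 2 lies beyond the scatter. Compound 3 `Nc1ccccc1NC(=O)c1ccc(CSCCc2ccccc2)cc1` has yet to be measured. It contains the same atoms as compound 1, joined differently, with phenethyl in place of 4-ethylphenyl on a sulfur. For the measured compounds named here, no measured pair of compounds differing in one place shows what such a change does, so the size of the step cannot be read from the data. The two groups match in what is counted, yet the value of compound 2, 10.6%, shows that this assay can read far lower than compound 1 does. A drop is therefore expected, though with wide uncertainty. The expected change is a number 34.1 percentage points lower from compound 1 to compound 3 (beyond the scatter), an estimated fall that would lie beyond the scatter. For compound 3 the estimated value is 45%, with an expected range from 15% to 75%.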

Compound 3, percent growth inhibition at one concentration: 81.3%
For compound 3 the middle estimate is 36.3 percentage points below the measured one; the whole stated range lies below it.
By their numbers in this assay, from the lowest: compound 2; then compounds 1 and 3 (each within the scatter of the next).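

Putting phenethyl in place of 4-ethylphenyl on a sulfur gives, in this assay, a number 2.2 percentage points higher from compound 1 to compound 3 (within the scatter), so at the concentration tested the two groups cannot be told apart at this position, even though the sulfur's link to the aromatic ring of the group is replaced by a saturated chain. Compound 3 also shows that phenethyl on a sulfur can go with strong growth inhibition: compound 2 carries the same group and gives 10.6%, while compound 3 gives 81.3%. Nothing in the data available here accounts for how well this position accepts the change.

On these data alone, it remains open whether the sulfur would keep this reading with a plain benzyl group, a longer chain such as 4-phenylbutyl, or an aromatic ring bearing an amine or a carboxylic acid. A reading at a single concentration also leaves open whether compound 1 and compound 3 would separate at lower concentrations.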